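The compounds below may be only part of what the source reports. "The series", "measured", "known", "first", "only" and "open" are said of these compounds alone.

Measured so far in an ADME assay on HEK-293T cells (Homo sapiens) for inhibition, read by CCK-8 assay, with a stated time of 48 h, tested at 20 uM; on this read-out higher numbers stand for more inhibition of growth at the one concentration tested and lower numbers for less inhibition of growth:
- compound 1 `Cc1ccc(S(=O)(=O)Oc2ccccc2/C=C(\C#N)C(=O)Nc2nnc(C)s2)cc1`: 35%
- compound 2 `Cc1ccc(S(=O)(=O)Oc2cccc(/C=C(\C#N)C(=O)Nc3nnc(-c4ccccc4)s3)c2)cc1`: 52%

Compound 2 stands highest of these two numbers, and its gap to compound 1 lies beyond the scatter. Compound 3 `COc1ccccc1-c1nnc(NC(=O)/C(C#N)=C/c2cccc(OS(=O)(=O)c3ccc(C)cc3)c2)s1` differs from compound 2 by methoxy in place of hydrogen on an aromatic carbon, which is methoxy in place of hydrogen on an aromatic carbon, or phenyl to 2-methoxyphenyl. Within the data shown here, no measured pair isolates a single change, so the data offer no direct guide to this one. In this assay, no step beyond the scatter is expected, with an estimated a number 2 percentage points lower from compound 2 to compound 3 (within the scatter). The expected value for compound 3 is 50%, with an estimated range of 35% to 65%.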

Compound 3, percent growth inhibition at one concentration: "not toxic" (no number reported)
No number was reported for compound 3; no gap can be computed for the estimate.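

Among these compounds, compound 3 is recorded as "not toxic" without a number in this assay and no step from compound 2 to compound 3 can be read. No supporting evidence bears on this result. As far as these compounds go, whether phenyl to 2-methoxyphenyl changes growth inhibition remains open.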